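Swapping a nitro for hydrogen on a chalcone arm

This account rests on a few compounds, and the source may have more. Where it says the series, first, only, none or still open, it means among the compounds named here.

Measured so far, in a functional assay on B16 cells (Mus musculus) for antiproliferative activity, read by MTT assay, with a stated time of 48 h; on this read-out higher numbers stand for weaker inhibition and lower numbers for stronger inhibition:
- compound 1, `CC1(C)Cc2c(OCc3ccccc3)ccc(C(=O)/C=C/c3cn(-c4ccccc4)nc3-c3ccc([N+](=O)[O-])cc3)c2O1`, gives > 100000 nM, which is a limit of the assay and not a number.
- compound 2, `CC1(C)Cc2c(ccc(C(=O)/C=C/c3cn(-c4ccccc4)nc3-c3ccccc3)c2OCc2ccccc2)O1`, gives > 100000 nM, again a limit rather than a number.
- compound 3, `CC1(C)Cc2c(ccc(C(=O)/C=C/c3ccc(Cl)cc3Cl)c2OCc2ccccc2)O1`, gives > 100000 nM, likewise a limit.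

Compound 1 therefore does not stand at any measured number: it sits at the limit, as do the other two compounds, since (the limit of > 100000 nM in this assay, at which 3 of the 3 values shown sit). Among the measured compounds shown here, no two of these three differ from one another in a single place, so no measured step between them can be computed, and the three values show only that none of the compounds reaches a measurable inhibition.

The unmeasured compound 4, `CC1(C)Cc2c(OCc3ccccc3)ccc(C(=O)/C=C/c3cn(-c4ccccc4)nc3-c3ccccc3)c2O1`, differs from compound 1 in one place: hydrogen in place of nitro on an aromatic carbon. Hydrogen in place of nitro on an aromatic carbon is a small removal on the outer arm of the shared core. With every shown value sitting at the limit, there is no measured step to lean on, and no reason from the data to expect the change to move compound 4 off that limit; the step from compound 1 to compound 4 is expected to be a step that the limit leaves unreadable from compound 1 to compound 4, meaning none beyond the scatter. Compound 4 is therefore estimated to come out at 150000 nM, between 60000 nM and 500000 nM, and most probably as a limit again.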

Compound 4, half-maximal inhibitory concentration: > 100000 nM
Compound 4 was reported as a limit (the forecaster's own chance of this, stated with the estimate: 85%); the middle value does not contradict the limit.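

Among the compounds shown here, compound 1 and compound 4 both come out as limits of the assay rather than as numbers, so no step between them can be read: the limit of > 100000 nM in this assay, at which 4 of the 4 values shown sit. The compounds shown leave open whether swapping 4-nitrophenyl to phenyl changes inhibition at all, and which change to the shared core would give a measurable number.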